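Three Weak Inhibitors and an Untested Methoxy Analogue

The source may hold more compounds than are shown below. What is called first, only, known or untested is meant among the compounds shown, and "the series" means these compounds.

Measured in a functional assay on HL-60 cells (Homo sapiens) for antiproliferative activity, read by MTT assay, with a stated time of 24 h; a higher number here means a weaker inhibitor, a lower number a stronger inhibitor:
compound 1 `CNC(=O)c1ccccc1Oc1nc(Nc2ccc(C(F)(F)F)cc2)ncc1Br`: > 50000 nM
compound 2 `CNC(=O)c1ccccc1Oc1nc(Nc2ccccc2F)ncc1Br`: > 50000 nM
compound 3 `CNC(=O)c1ccccc1Oc1nc(Nc2cccc(Br)c2)ncc1Br`: 38700 nM

In this assay compound 2 gives > 50000 nM, which is a limit of the assay and not a number. At that limit sit (the limit of > 50000 nM in this assay, at which 2 of the 3 values shown sit). Compound 4 `CNC(=O)c1ccccc1Oc1nc(Nc2ccccc2OC)ncc1Br` differs from compound 2 by methoxy in place of fluoro on an aromatic carbon. Among the compounds with values here, the only measured step from compound 2 is an at least 1.2-fold lower number from compound 2 to compound 3 (0.11 log units; that floor lies within the scatter), and it changes the ring-bound group at a different place. Within the data shown here, no measured step touches methoxy for fluoro, and since compound 2 is known only as a limit, no size can be read from it. Compound 4 is therefore expected to stay weak, with an estimated step of an at least 1.1-fold lower number from compound 2 to compound 4 (0.04 log units; that floor lies within the scatter). The estimate for compound 4 is 45000 nM, ranging from 15000 nM to 120000 nM.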

Compound 4, half-maximal inhibitory concentration: > 50000 nM
Compound 4 gave a limit, no number (the forecaster's own chance of this, stated with the estimate: 55%); at least 1.1-fold (0.04 log units) between middle value and limit.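

In this assay, methoxy in place of fluoro on this aromatic carbon, ortho to a large group, still leaves compound 4 at a limit of the assay and not at a number, and the step from compound 2 cannot be read. Within the data shown here, the one comparison with a measured number gives an at least 1.2-fold higher number from compound 3 to compound 4 (0.11 log units; that floor lies within the scatter). The new result adds to the values held at the limit: the limit of > 50000 nM in this assay, at which 3 of the 4 values shown sit. From the compounds shown here alone, whether an amine or a hydroxyl group on this carbon, or a longer chain such as ethoxy, would give a readable number stays open.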